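Oxygen-linked side chains on the shared core

The source may report more compounds than this note shows. Statements on the series, on what has been measured and on what is new or still open speak of the compounds shown alone.

Of the compounds shown here, two define the series so far. Compound 1 `CN1CCN(c2nc3ccccc3n2CCOc2ccccc2)CC1` gives 6.9 nM in a functional assay on ileum for inhibition of histamine H1 receptor (Cavia porcellus); on this read-out higher numbers stand for weaker inhibition and lower numbers for stronger inhibition. Within the data shown here, compound 2 `CCCCCCCn1c(N2CCN(C)CC2)nc2ccccc21` gives 150 nM in this assay, the highest of the two numbers; the only step to it, a 22-fold higher number from compound 1 to compound 2 (1.34 log units; beyond the scatter), shows how far the heptyl chain lies from the phenoxy-bearing one. Compound 3 `C#CCOCCn1c(N2CCN(C)CC2)nc2ccccc21` is not yet measured. The change propargyloxy in place of pentyl on a saturated chain carbon, two bonds along the chain from an aromatic nitrogen brings an oxygen back into the chain at the same place where compound 1 carries its phenoxy, yet the propargyl end is much smaller than the phenyl ring of compound 1. The step from compound 1 to compound 2 is the only one that bears on this, and it points toward a lower number with an oxygen in the chain. A partial return is therefore expected, a 5.0-fold lower number from compound 2 to compound 3 (0.70 log units; beyond the scatter), landing between the two measured compounds. Compound 3 is estimated at 30 nM in this assay, with a range of 8 nM to 120 nM.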

Compound 3, half-maximal inhibitory concentration: 12 nM
Estimate against measurement, compound 3: 2.5-fold (0.40 log units) above, and the stated range covers the measured number.
By their numbers in this assay, from the lowest: compounds 1 and 3 (each within the scatter of the next); then compound 2.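

At this place on the chain, propargyloxy in place of pentyl gives a 13-fold lower number from compound 2 to compound 3 (1.10 log units; beyond the scatter) in this assay, so a small oxygen-bearing end reaches the range of compound 1 and not merely part of the way there. The phenyl of compound 1 turns out not to be required for this level, as propargyl in place of phenyl on the oxygen gives a 1.7-fold higher number from compound 1 to compound 3 (0.24 log units; within the scatter), and the two ether ends cannot be told apart on this read-out. No measured data offer an explanation for either step.

The step from compound 2 to compound 3 brings in the oxygen and the triple bond together, leaving their shares unseparated; a saturated propoxy end would bear on this. Also open, from the compounds shown here alone, is whether a methoxy end or a longer ether chain holds the same level.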